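This account rests on a few compounds, and the source may have more. Where it says the series, first, only, none or still open, it means among the compounds named here.

In a functional assay on SK-OV-3 cells (Homo sapiens) for cytotoxicity (a lower number here means a stronger inhibitor of growth, a higher number a weaker inhibitor of growth), compound 1 (`COc1ccc(C2=C(c3ccc(SC)cc3)CC3CCCN3C2=O)cc1OC(=O)CNC(=O)OC(C)(C)C`) gives 20000 nM and compound 2 (`COc1ccc(C2=C(c3ccc(SC)cc3)CC3CCCN3C2=O)cc1C`) gives 15000 nM as its measured value. These two numbers lie within the usual scatter of each other, so compound 2 stands level with compound 1, and neither can be ranked ahead of the other.

Compound 3 (`COc1ccc(C2=C(c3ccc(SC)cc3)CC3CCCN3C2=O)cc1OC`) differs from compound 2 by methoxy in place of methyl on an aromatic carbon. Among the measured compounds shown here, only one measured step bears on this change, and only indirectly. The step of a 1.3-fold lower number from compound 1 to compound 2 (0.12 log units; within the scatter) replaced a far larger group with a methyl on that same aromatic carbon, and it stayed within the scatter. For the measured compounds named here, no measured compound yet shows a methoxy there, so this single step is thin evidence. Still, if so large an exchange moved the number so little, a much smaller exchange gives no reason to predict a real shift in either direction. The expected step of a 1.1-fold lower number from compound 2 to compound 3 (0.03 log units; within the scatter) therefore stays within the scatter. For compound 3 the estimate is 14000 nM with an expected range of roughly (5000 nM to 35000 nM).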

Compound 3, concentration for 50% growth inhibition: 9000 nM
Beside the measured number, compound 3's estimate is 1.6-fold (0.19 log units) above it; the range from low to high includes it.
By their numbers in this assay, from the lowest: compounds 3, 2 and 1 (each within the scatter of the next, the first and the last beyond it).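

In this assay this series now has its first step beyond the scatter, a 2.2-fold lower number from compound 1 to compound 3 (0.35 log units; beyond the scatter), and it comes from changing only what sits on the oxygen attached to the aromatic ring, with that oxygen kept in place. The smaller exchange of methoxy in place of methyl on the same aromatic carbon gives a 1.7-fold lower number from compound 2 to compound 3 (0.22 log units; within the scatter), so on its own this change cannot be told apart from the ordinary spread of repeated measurements. Among the compounds shown here, the position is therefore not wholly indifferent to what it carries, although the one step that shows this is modest and no accompanying measurement says why.

The compounds shown leave open whether a free hydroxyl, an amine or a longer chain such as ethoxy on that aromatic carbon would take the number further from that of compound 3, and in which direction. They also leave open what the methoxy group shared by all three compounds contributes to growth inhibition in these cells.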